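Aryl ether fluorine position: compound 3 to compound 4

The compounds below may be only part of what the source reports. "The series", "measured", "known", "first", "only" and "open" are said of these compounds alone.

Compounds measured so far, with their values in a functional assay on CHO cells for agonist activity at prostaglandin E2 receptor EP2 subtype (Homo sapiens), read by HTRF and cAMP accumulation, with a stated time of 30 min; a lower number here means that less compound is needed, a higher number that more compound is needed for the effect:
compound 1 `O=C(O)c1csc([C@H]2CC[C@@H]3[C@@H](/C=C/[C@@H](O)COc4ccccc4)[C@H](O)C[C@@H]3O2)n1` gives 7.9 nM
compound 2 `Cc1cccc(OC[C@@H]2[C@H]3CC[C@H](c4nc(C(=O)O)cs4)O[C@H]3C[C@H]2O)c1` gives 3.6 nM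
compound 3 `O=C(O)c1csc([C@H]2CC[C@@H]3[C@@H](COc4ccc(F)cc4)[C@H](O)C[C@@H]3O2)n1` gives 7 nM

Compound 3 holds the second highest of the three numbers; its gap to compound 1 and its gap to compound 2 both lie within the scatter, so the three compounds cannot be ordered against each other. Compound 4 `O=C(O)c1csc([C@H]2CC[C@@H]3[C@@H](COc4cccc(F)c4)[C@H](O)C[C@@H]3O2)n1` differs from compound 3 in one place: 3-fluorophenyl in place of 4-fluorophenyl on an oxygen on a saturated carbon. For the measured compounds named here, the only measured step at this place is a 1.9-fold higher number from compound 2 to compound 3 (0.29 log units; within the scatter), which did not move the number beyond the scatter; no step exchanging two fluorophenyl groups has been measured. The step of a 1.1-fold lower number from compound 3 to compound 4 (0.03 log units; within the scatter) is therefore expected to stay within the scatter, with no direction favoured. Compound 4 is estimated at 6.5 nM in this assay, with a range of 2.5 nM to 16 nM.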

Compound 4, half-maximal effective concentration: 5.4 nM
Estimate against measurement, compound 4: 1.2-fold (0.08 log units) above; the range from low to high includes it.
By their numbers in this assay, from the lowest: compounds 2, 4, 3 and 1 (each within the scatter of the next, the first and the last beyond it).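

In this assay, exchanging 4-fluorophenyl for 3-fluorophenyl gives a 1.3-fold lower number from compound 3 to compound 4 (0.11 log units; within the scatter), so this change of fluorine position on the aryl ether does not separate the two compounds. Fluoro in place of methyl on an aromatic carbon gives a 1.5-fold higher number from compound 2 to compound 4 (0.18 log units; within the scatter), so this exchange of substituent also stays within the scatter. No evidence bears on either step. Still open, as far as these compounds go, is whether an amine or a nitrile on this phenyl, or a longer chain in place of (3-fluorophenoxy)methyl, would produce a step beyond the scatter.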